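The source may report more compounds than this note shows. Statements on the series, on what has been measured and on what is new or still open speak of the compounds shown alone.

Measured in a functional assay on KBVIN cells (Homo sapiens) for antiproliferative activity, read by sulforhodamine B assay, with a stated time of 3 days; on this read-out lower numbers stand for stronger inhibition of growth and higher numbers for weaker inhibition of growth:
- compound 1 `COc1ccc(N2CCN(C)CC2)cc1Nc1ncc(F)c(Nc2ccc(F)cc2)n1`: 910 nM
- compound 2 `O=C(Nc1ccc(C(F)(F)F)cc1)c1cccc(Nc2ncc(F)c(Nc3ccc(F)cc3)n2)c1`: > 10000 nM (a limit of the assay, not a number)
- compound 3 `O=C(Nc1cccc(Nc2ncc(F)c(Nc3ccc(F)cc3)n2)c1)c1cnccn1`: 20100 nM

Of the two true numbers, compound 3 at 20100 nM holds the higher one. Compound 1 reads 910 nM, and the gap between the two lies beyond the scatter.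

Compound 4 `O=C(Nc1cccc(Nc2ncc(F)c(Nc3ccc(F)cc3)n2)c1)c1ccncc1` carries pyridin-4-yl in place of pyrazin-2-yl on a carbonyl carbon.

For the measured compounds named here, no measured step covers this swap, so the expectation rests on compound 3 at 20100 nM and the change alone. In this assay a small move toward lower numbers is expected, near the edge of the scatter. The estimated step is a 2.2-fold lower number from compound 3 to compound 4 (0.35 log units; beyond the scatter). The expected value for compound 4 is 9000 nM, with an estimated range of 2500 nM to 30000 nM.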

Compound 4, concentration for 50% growth inhibition: 4570 nM
For compound 4 the middle estimate is 2.0-fold (0.29 log units) above the measured one, within the range that was stated.
By their numbers in this assay, from the lowest: compound 1; then compound 4; then compound 3.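

In this assay, pyridin-4-yl in place of pyrazin-2-yl on a carbonyl carbon gives a 4.4-fold lower number from compound 3 to compound 4 (0.64 log units; beyond the scatter). For the compounds shown here, this is the first step that can be read, and it shows that the ring on this carbonyl carbon affects growth inhibition, with the number moving beyond the scatter when one ring nitrogen replaces two.

Compound 2 carries a limit, not a number, and cannot be set against this step: the limit of > 10000 nM in this assay, at which 1 of the 4 values shown sits. Open, going by these compounds, is how a plain phenyl ring, or a saturated amine such as piperidin-4-yl, would read on the same carbonyl carbon.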